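A few compounds are considered here, and "the series" means these few. Any claim that something is new, unique, unknown or untested is made for them only; others in the source may bear on it.

Three related compounds have been tested in a functional assay on MT4 cells (Homo sapiens) for cytotoxicity, read by MTT assay; a higher number here means that more compound is tolerated, a lower number that less compound is tolerated. Compound 1 (`COc1ccc(CSc2nc(O)c(C)c(Cc3c(Cl)cccc3Cl)n2)c(OC)c1`) reads > 55000 nM, which is a limit of the assay and not a number. Compound 3 (`COc1ccc(CSc2nc(O)c(C)c(Cc3c(F)cccc3F)n2)cc1`) reads > 64000 nM, which is likewise a limit. Among the measured compounds shown here, compound 2 (`Cc1c(O)nc(SCc2ccc(O)cc2)nc1Cc1c(Cl)cccc1Cl`) gives 41000 nM, the only true number among the three, which makes it the single firm reference point in this assay.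

Compound 4 (`Cc1c(O)nc(SCc2ccc([N+](=O)[O-])cc2)nc1Cc1c(Cl)cccc1Cl`) has not yet been measured. It differs from compound 2 in one place: nitro in place of hydroxy on an aromatic carbon. Put simply, compound 4 carries a 4-nitrophenyl where compound 2 carries a 4-hydroxyphenyl.

For the measured compounds named here, no two measured compounds here differ in just one place, so the data give no direct measure of what a single change of this kind can do. The expectation therefore starts from compound 2 at 41000 nM, with no change beyond the usual scatter and no favoured direction, although the uncertainty is wide. The estimated step of a 1.2-fold lower number from compound 2 to compound 4 (0.07 log units; within the scatter) is accordingly small. For compound 4 the expected value is 35000 nM, within an estimated range of 12000 nM to 90000 nM.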

Compound 4, half-maximal cytotoxic concentration: > 58000 nM
Compound 4 was reported as a limit (the forecaster's own chance of this, stated with the estimate: 45%); at least 1.6-fold (0.21 log units) between middle value and limit.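

Among the compounds shown here, this is the first change that can be read on its own: in this assay, putting nitro in place of hydroxy on an aromatic carbon, para to a large group, gives an at least 1.4-fold higher number from compound 2 to compound 4 (0.15 log units; that floor lies within the scatter). Even that smallest possible step does not lie beyond the scatter, so the result shows only that this swap brings no drop in the tolerated amount, and it does not establish a true rise. Compound 4 gives > 58000 nM, which is a limit of the assay and not a number, so the full size of the step cannot be read and compound 2 remains the only compound with a firm number: the limit of > 58000 nM in this assay, at which 1 of the 4 values shown sits.

The compounds shown leave open how an amine or a carboxylic acid at this same place on the ring would read, and whether a firm number could be obtained for any group that replaces hydroxy here. They also leave open whether the swap from 4-hydroxyphenyl to 4-nitrophenyl would read the same way with fluorine in place of chlorine on the other aromatic ring.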